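Swapping a phenyl for pyridin-2-yl on the shared core

The compounds below may be only part of what the source reports. "The series", "measured", "known", "first", "only" and "open" are said of these compounds alone.

Of the compounds shown here, three built on one core have been tested in an assay on isolated protein for inhibition of DNA topoisomerase 1 (Homo sapiens), with a stated time of 30 min, tested at 100 uM; on this read-out higher numbers stand for a stronger effect at the one concentration tested and lower numbers for a weaker effect. Compound 1 `Oc1cccc(-c2cc(-c3cccc(Cl)c3)nc(-c3ccccn3)c2)c1` gives 0.4%, compound 2 `Oc1cccc(-c2cc(-c3ccsc3)nc(-c3ccccc3Cl)c2)c1` gives 0%, and compound 3 `Oc1cccc(-c2cc(-c3ccccc3)nc(-c3ccccc3Cl)c2)c1` gives 3.2%. Compound 3 has the highest of the three numbers, but its gap to compound 1 and its gap to compound 2 both lie within the usual scatter, so the three are effectively level. Within the data shown here, the one measured step, a number 3.2 percentage points higher from compound 2 to compound 3 (within the scatter), is likewise within the scatter.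

Compound 4 `Oc1cccc(-c2cc(-c3ccccn3)nc(-c3ccccc3Cl)c2)c1` is the next compound. It differs from compound 3 in one place: pyridin-2-yl in place of phenyl on an aromatic carbon. Among the measured compounds shown here, no measured step tests exactly this change on this core. Compound 1 does carry a pyridin-2-yl group, together with a 3-chlorophenyl group rather than the 2-chlorophenyl group of compound 4, and its value sits close to that of compound 3. For the measured compounds named here, since every number so far is near zero and every step is within the scatter, the expected step of a number 1.7 percentage points lower from compound 3 to compound 4 (within the scatter) is none beyond the scatter. Compound 4 is therefore estimated at 1.5%, in the range from 0% to 8% in this assay.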

Compound 4, a percentage reported as inhibition, at one concentration (the size of the read-out at that concentration, not a potency): 0%
For compound 4 the middle estimate is 1.5 percentage points above the measured one, and the stated range covers the measured number.
By their numbers in this assay, from the lowest: compounds 2, 4, 1 and 3 (each within the scatter of the next).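

Pyridin-2-yl in place of phenyl at this position, with its ring nitrogen and one hydrogen-bond acceptor, is now tested directly in this assay and gives a number 3.2 percentage points lower from compound 3 to compound 4 (within the scatter) on the shared core, while the swap from thiophen-3-yl gives no change at the digits printed from compound 2 to compound 4 (within the scatter) at the same position. The other swap, 2-chlorophenyl in place of 3-chlorophenyl, gives a number 0.4 percentage points lower from compound 1 to compound 4 (within the scatter) when pyridin-2-yl is present, so neither change separates these compounds. Nothing available offers a reason for these flat results.

With all four compounds this close to zero at one concentration, these aromatic groups cannot be ranked against one another. On these data alone, whether an amine, a carboxylic acid or a longer chain at this position would raise the number remains open.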